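The source may report more compounds than this note shows. Statements on the series, on what has been measured and on what is new or still open speak of the compounds shown alone.

Measured so far in a functional assay on HepG2 cells (Homo sapiens) for cytotoxicity, read by MTT assay, with a stated time of 72 h; on this read-out lower numbers stand for stronger inhibition and higher numbers for weaker inhibition:
- compound 1 `Cc1c(C)c2c(c(C)c1OC(=O)CCC(=O)NC1CC(C)(C)N([O])C1(C)C)CC[C@@](C)(CCC[C@H](C)CCC[C@H](C)CCCC(C)C)O2`: > 300000 nM (a limit, not a number)
- compound 2 `Cc1c(C)c2c(c(C)c1OC(=O)CCC(=O)O)CCC(C)(C(=O)O)O2`: 242000 nM

For the measured compounds named here, compound 2 gives 242000 nM, the only true number available, so there is no measured step to compare it with. Compound 1 gives > 300000 nM, which is a limit and not a number.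

Compound 3 `Cc1c(C)c2c(c(C)c1OC(=O)CCC(=O)O)CCC(C)(C(=O)NC1CC(C)(C)N([O])C1(C)C)O2` keeps the core of compound 2 and changes in one place, on a carbonyl carbon whose other neighbour is a saturated ring carbon: a group of 11 heavy atoms (8 carbon, 2 nitrogen, 1 oxygen; one five-membered non-aromatic ring with 1 hetero atom) in place of one oxygen atom, on a carbonyl carbon. The incoming group brings a five-membered non-aromatic ring, and compound 1 carries a ring of the same kind.

Going by the values given here, with no measured step as a guide, no change beyond the scatter is expected in this assay. The expected result is a 1.2-fold lower number from compound 2 to compound 3 (0.08 log units; within the scatter), a small estimated step. For compound 3 the estimate is 200000 nM, with an expected range from 80000 nM to 450000 nM.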

Compound 3, half-maximal inhibitory concentration: > 300000 nM
Compound 3 gave a limit, no number (the forecaster's own chance of this, stated with the estimate: 35%); middle value at least 1.5-fold (0.17 log units) away from the limit.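

Exchanging the hydroxy on this carbonyl carbon for a group of 11 heavy atoms with a five-membered non-aromatic ring gives an at least 1.2-fold higher number from compound 2 to compound 3 (0.09 log units; that floor lies within the scatter) in this assay. On these data alone, the step is only a floor, so its true size is unknown, but the exchange at this place did not lower the number. Compound 3, like compound 1, which carries a ring of the same kind, gives a limit and not a number: the limit of > 300000 nM in this assay, at which 2 of the 3 values shown sit.

As far as these compounds go, how far beyond that limit compound 3 lies stays open, as does whether a smaller group on this carbonyl carbon, such as a methyl ester or a plain amide, would behave in the same way. The compounds shown also cannot separate the contribution of the ring from that of the amide link that joins it.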